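Replacing the hydroxy of compound 3 with ethylsulfanyl

This account rests on a few compounds, and the source may have more. Where it says the series, first, only, none or still open, it means among the compounds named here.

Compound 3 `Oc1ccc(-c2ccc(NCc3ccccc3O)cc2)cc1` was tested in a functional assay on Jurkat cells (Homo sapiens) for activation, with a stated time of 24 h (on this read-out lower numbers stand for an effect already at smaller amounts and higher numbers for an effect only at larger amounts of compound), and for compound 3 the outcome was recorded as "not active" (no number reported), with no number given. Its relatives share the same core: compound 1 `COc1ccc(-c2ccc(NCc3ccccc3O)cc2)cc1` gives 580 nM, whereas compound 2 `Oc1ccccc1CNc1ccc(-c2ccc(OC(F)(F)F)cc2)cc1` is reported as "not active" (no number reported). Compound 4 `CCSc1ccc(-c2ccc(NCc3ccccc3O)cc2)cc1` has not yet been measured. It differs from compound 3 by ethylsulfanyl in place of hydroxy on an aromatic carbon, on an aromatic carbon of a six-membered aromatic ring of carbon only, para to a large group. From the compounds shown here alone, since compound 3 carries no number, no step size can be computed, and the direction remains open. Compound 4 is expected to come in around 1500 nM, estimated between 300 nM and 8000 nM, with a real chance that this assay again reports no number.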

Compound 4, half-maximal effective concentration: 1980 nM
Compound 4: the middle estimate sits 1.3-fold (0.12 log units) below what was measured, within the range that was stated.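

Compound 4 shows that ethylsulfanyl on this aromatic carbon, para to a large group, still gives a number in this assay, whereas hydroxy in compound 3 gave none, so that step cannot be read as a size. Ethylsulfanyl in place of methoxy gives a 3.4-fold higher number from compound 1 to compound 4 (0.53 log units; beyond the scatter), so activity here is not confined to methoxy, though ethylsulfanyl does not improve on it. Nothing available explains this difference.

From the compounds shown here alone, whether an amine, a carboxylic acid or a longer thioether chain at this position would give a number, and how it would compare with methoxy, stays open.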